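Chain extension from compound 3 to compound 4

The source may report more compounds than this note shows. Statements on the series, on what has been measured and on what is new or still open speak of the compounds shown alone.

The series shares one core and varies the group on the chain carbon attached to the amine. Compound 1 `[O-][n+]1nc(NCOCc2ccccc2)[n+]([O-])c2ccccc21`, compound 2 `CCCOCNc1n[n+]([O-])c2ccccc2[n+]1[O-]` and compound 3 `CCOCNc1n[n+]([O-])c2ccccc2[n+]1[O-]` have been measured. In a functional assay on PC-3 cells (Homo sapiens) for cytotoxicity, read by MTT assay, with a stated time of 72 h (on this read-out higher numbers stand for weaker inhibition and lower numbers for stronger inhibition), compound 1 gives 13400 nM, compound 2 gives 14200 nM and compound 3 gives 15900 nM. On these numbers compound 3 stands level with the other two: a 1.2-fold higher number from compound 1 to compound 3 (0.07 log units; within the scatter) and a 1.1-fold higher number from compound 2 to compound 3 (0.05 log units; within the scatter), both within the scatter, as is a 1.1-fold higher number from compound 1 to compound 2 (0.03 log units; within the scatter).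

Compound 4 `CCCCCOCNc1n[n+]([O-])c2ccccc2[n+]1[O-]` is the next member; it differs from compound 3 by propyl in place of hydrogen on a saturated chain carbon, two bonds along the chain from an oxygen on a saturated carbon. For the measured compounds named here, the one step that bears on this place directly runs the other way, a 1.1-fold higher number from compound 2 to compound 3 (0.05 log units; within the scatter), and lay within the scatter; the two steps exchanging phenyl for ethyl or methyl at the neighbouring chain carbon were also within the scatter. Nothing in the measured steps points to a move beyond the scatter, so the expected step is a 1.2-fold lower number from compound 3 to compound 4 (0.09 log units; within the scatter). Compound 4 is therefore estimated at 13000 nM in this assay, with a range from 6500 nM to 26000 nM.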

Compound 4, half-maximal inhibitory concentration: 9200 nM
The estimate for compound 4 lay 1.4-fold (0.15 log units) above the measured number; the measured number falls inside the stated range.
By their numbers in this assay, from the lowest: compounds 4, 1, 2 and 3 (each within the scatter of the next).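

In this assay, for the compounds shown here, the change from ethoxy to pentyloxy, a larger change at this place than the earlier steps covered, brings a 1.7-fold lower number from compound 3 to compound 4 (0.24 log units; within the scatter) and so does not separate the two compounds. Ethyl in place of hydrogen, three bonds along the chain from an oxygen on a saturated carbon, brings a 1.5-fold lower number from compound 2 to compound 4 (0.19 log units; within the scatter) and likewise leaves that pair level. Exchanging the phenyl group for a butyl group brings a 1.5-fold lower number from compound 1 to compound 4 (0.16 log units; within the scatter) and shows that this open chain and the phenyl group also stand level on this read-out.

As far as these compounds go, whether a longer chain, or an amine or a carboxylic acid in place of the propyl, would carry the number beyond the scatter stays open. No supporting measurement bears on the reason for these numbers.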